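A Side Chain Swap With One Measured Step

This account rests on a few compounds, and the source may have more. Where it says the series, first, only, none or still open, it means among the compounds named here.

- Compound 1 `COc1ccc(NC(=O)CCSc2ccc3c(/C=C/c4ccccn4)n[nH]c3c2)cc1C(F)(F)F`: > 10000 nM, which is a limit
- Compound 2 `CN(C)CCN(C)Cc1ccc(NC(=O)CCSc2ccc3c(/C=C/c4ccccn4)n[nH]c3c2)cc1C(F)(F)F`: 1850 nM

Going by the values given here, in an ADME assay on BaF3 cells (Mus musculus) for antiproliferative activity, read by CCK-8 assay, with a stated time of 72 h (a lower number here means a stronger inhibitor of growth, a higher number a weaker inhibitor of growth), compound 2 gives 1850 nM, the only actual number so far. Compound 3 `CC1CCN(Cc2ccc(NC(=O)CCSc3ccc4c(/C=C/c5ccccn5)n[nH]c4c3)cc2C(F)(F)F)CC1` keeps the shared core of compound 2 but carries 4-methylpiperidin-1-yl in place of (2-(dimethylamino)ethyl)(methyl)amino on a saturated chain carbon bound to an aromatic carbon. Among the compounds with values here, one measured step bears on this change: an at least 5.4-fold lower number from compound 1 to compound 2 (0.73 log units; beyond the scatter). Its size rests on (the limit of > 10000 nM in this assay, at which 1 of the 2 values shown sits). That step brought in the whole side chain in place of methoxy, so it does not compare the two amine ends directly. Within the data shown here, with no measured step for such a swap, no shift beyond the scatter is expected in this assay. The expected change is a 1.2-fold lower number from compound 2 to compound 3 (0.06 log units; within the scatter). Compound 3 is estimated at 1600 nM, with an expected range of 500 nM to 6000 nM.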

Compound 3, concentration for 50% growth inhibition: 4170 nM
Estimate against measurement, compound 3: 2.6-fold (0.42 log units) below; low and high end bracket the measured number.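

In this assay, the identity of the amine end matters at this position: 4-methylpiperidin-1-yl in place of (2-(dimethylamino)ethyl)(methyl)amino on a saturated chain carbon bound to an aromatic carbon gives a 2.3-fold higher number from compound 2 to compound 3 (0.35 log units; beyond the scatter), a modest loss that no earlier comparison could show. The ring-bearing side chain still improves on methoxy, as (4-methylpiperidin-1-yl)methyl in its place gives an at least 2.3-fold lower number from compound 1 to compound 3 (0.37 log units; beyond the scatter). The true size of that step stays unknown, and it rests on a limit: the limit of > 10000 nM in this assay, at which 1 of the 3 values shown sits.

The compounds shown leave open whether the loss goes with the open chain giving way to a ring or with the loss of the second nitrogen, as the two changes arrive together here. A 4-methylpiperazin-1-yl group, with both a ring and a second nitrogen, would separate them.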